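Carbamoyl in Place of Amino: What to Expect

This account rests on a few compounds, and the source may have more. Where it says the series, first, only, none or still open, it means among the compounds named here.

Among the measured compounds shown here, compound 2 `COc1ccc(/C=C2\c3cc(OC)c(OC)c(OC)c3CC[C@H]2O)cc1N` gives 910 nM in a functional assay on HT-29 cells (Homo sapiens) for inhibition, read by MTT assay (on this read-out lower numbers stand for stronger inhibition and higher numbers for weaker inhibition), the higher of the two numbers known here; its nearest neighbour, compound 1 `COc1ccc(/C=C2\c3cc(OC)c(OC)c(OC)c3CC[C@H]2O)cc1F`, gives 220 nM in this assay. For the measured compounds named here, the only measured step, a 4.1-fold higher number from compound 1 to compound 2 (0.62 log units; beyond the scatter), concerns a different exchange on the same aromatic carbon. Compound 3 `COc1ccc(/C=C2\c3cc(OC)c(OC)c(OC)c3CC[C@H]2O)cc1C(N)=O` carries carbamoyl in place of amino on an aromatic carbon. Going by the values given here, no measured step covers this change, so the expectation rests only on the modest size of the one known step. Compound 3 is estimated at 1500 nM (range 400 nM to 6000 nM) in this assay. That estimate corresponds to an expected step of a 1.6-fold higher number from compound 2 to compound 3 (0.22 log units; within the scatter).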

Compound 3, half-maximal inhibitory concentration: 550 nM
Compound 3: middle estimate off by 2.7-fold (0.44 log units), on the high side, and the stated range covers the measured number.
By their numbers in this assay, from the lowest: compound 1; then compounds 3 and 2 (each within the scatter of the next).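

In this assay, carbamoyl in place of amino gives a 1.7-fold lower number from compound 2 to compound 3 (0.22 log units; within the scatter), so on this aromatic carbon, ortho to a methoxy group, the two groups cannot be told apart on this read-out. Fluoro still stands apart from carbamoyl, with a 2.5-fold higher number from compound 1 to compound 3 (0.40 log units; beyond the scatter), as it does from amino, with a 4.1-fold higher number from compound 1 to compound 2 (0.62 log units; beyond the scatter). Nothing measured here accounts for these numbers.

Going by these compounds, whether a nitrile, a carboxylic acid or a longer chain on this carbon would fall with fluoro or with amino and carbamoyl stays open. So does whether the same order holds in cells other than those of this assay.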